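The source may hold more compounds than are shown below. What is called first, only, known or untested is meant among the compounds shown, and "the series" means these compounds.

In a functional assay on HT-29 cells (Homo sapiens) for inhibition, read by luminescence and CellTiter-Glo, with a stated time of 24 h (a lower number here means that less compound is needed, a higher number that more compound is needed for the effect), compound 1 (`CCCn1nc(C(=O)N[C@H]2COc3ccccc3N(C)C2=S)nc1Cc1ccccc1`) gives 288 nM, compound 2 (`CC(C)Cn1nc(C(=O)N[C@H]2COc3ccccc3N(C)C2=S)nc1Cc1ccccc1`) gives 1230 nM and compound 3 (`CN1C(=S)[C@@H](NC(=O)c2nc(Cc3ccccc3)n(CCCO)n2)COc2ccccc21`) gives 209 nM. Compound 3 thus stands at the low end of these numbers, level with compound 1 within the scatter: a 1.4-fold lower number from compound 1 to compound 3 (0.14 log units; within the scatter). Compound 2 lies clearly apart, shown by a 4.3-fold higher number from compound 1 to compound 2 (0.63 log units; beyond the scatter) and a 5.9-fold lower number from compound 2 to compound 3 (0.77 log units; beyond the scatter). Compound 4 (`CN1C(=S)[C@@H](NC(=O)c2nc(Cc3ccccc3)n(CCCCC#N)n2)COc2ccccc21`) differs from compound 3 by cyanomethyl in place of hydroxy on a saturated chain carbon, three bonds along the chain from an aromatic nitrogen, which turns 3-hydroxypropyl into 4-cyanobutyl. Among the measured compounds shown here, no measured step makes this exact exchange. The closest is the hydroxy step at the same carbon, a 1.4-fold lower number from compound 1 to compound 3 (0.14 log units; within the scatter), so no change beyond the scatter is expected in this assay, though a small rise is possible. The estimated step is a 1.4-fold higher number from compound 3 to compound 4 (0.16 log units; within the scatter). Compound 4 is expected at 300 nM, with an estimated range of 100 nM to 900 nM.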

Compound 4, half-maximal effective concentration: 2680 nM
For compound 4 the middle estimate is 8.9-fold (0.95 log units) below the measured one; measured number above the stated range.
By their numbers in this assay, from the lowest: compounds 3 and 1 (each within the scatter of the next); then compound 2; then compound 4.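

In this assay, among the compounds shown here, this chain position proves far less forgiving than the earlier compounds suggested: 4-cyanobutyl in place of 3-hydroxypropyl brings a large rise (a 13-fold higher number from compound 3 to compound 4 (1.11 log units; beyond the scatter)). The rise holds against the other two chains (a 9.3-fold higher number from compound 1 to compound 4 (0.97 log units; beyond the scatter); a 2.2-fold higher number from compound 2 to compound 4 (0.34 log units; beyond the scatter)), so the longer nitrile chain gives the highest number of the four. No evidence at hand accounts for this rise. The compounds shown leave open whether the nitrile or the longer chain carries the rise; a plain pentyl chain or a 3-cyanopropyl chain would help separate the two. From the compounds shown here alone, how an amine in place of the hydroxy would read also stays open.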